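The source may hold more compounds than are shown below. What is called first, only, known or untested is meant among the compounds shown, and "the series" means these compounds.

Of the compounds shown here, three with the shared core have been measured in a functional assay on NCI-H460 cells (Homo sapiens) for cytotoxicity, read by MTT assay, with a stated time of 72 h; a lower number here means a stronger inhibitor, a higher number a weaker inhibitor. Compound 1 `CN(C)CCn1cnnc1-c1cc(Oc2ccc(NC(=O)N/N=C/c3ccccc3O[N+](=O)[O-])cc2F)ccn1` gives 1270 nM, compound 2 `CN(C)CCn1cnnc1-c1cc(Oc2ccc(NC(=O)N/N=C/c3ccc(Cl)cc3)cc2F)ccn1` gives 320 nM, and compound 3 `CN(C)CCn1cnnc1-c1cc(Oc2ccc(NC(=O)N/N=C/c3ccc(O)cc3)cc2F)ccn1` gives 1780 nM. Compound 3 therefore carries the highest of the three numbers; compound 1 sits close to it, while the step of a 5.6-fold higher number from compound 2 to compound 3 (0.75 log units; beyond the scatter) is the one clear difference among them. Compound 4 `CN(C)CCn1cnnc1-c1cc(Oc2ccc(NC(=O)N/N=C/c3cccc(O)c3)cc2F)ccn1` differs from compound 3 only in the group on the carbon with a double bond to nitrogen: 3-hydroxyphenyl in place of 4-hydroxyphenyl on a carbon with a double bond to nitrogen. Among the compounds with values here, no measured step moves a hydroxy group from one ring position to another, so none bears directly on this change. The steps that touch the 4-hydroxyphenyl group, a 1.4-fold higher number from compound 1 to compound 3 (0.15 log units; within the scatter) and a 5.6-fold higher number from compound 2 to compound 3 (0.75 log units; beyond the scatter), replace it wholesale and say nothing about where the hydroxy sits. Within the data shown here, with no direct precedent, a step no larger than the scatter is expected, in no firm direction. Compound 4 is estimated at 1500 nM, within 600 nM to 4000 nM, a step of a 1.2-fold lower number from compound 3 to compound 4 (0.07 log units; within the scatter).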

Compound 4, half-maximal inhibitory concentration: 780 nM
Beside the measured number, compound 4's estimate is 1.9-fold (0.28 log units) above it; the range from low to high includes it.
By their numbers in this assay, from the lowest: compound 2; then compounds 4, 1 and 3 (each within the scatter of the next, the first and the last beyond it).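

Moving the hydroxy group, with the same atoms and the same counted donor and acceptor, is enough to change the result in this assay (a 2.3-fold lower number from compound 3 to compound 4 (0.36 log units; beyond the scatter)), so at this place the 3-hydroxyphenyl and 4-hydroxyphenyl groups are not interchangeable, which no earlier step could show. The change does not reach the 4-chlorophenyl group of compound 2 (a 2.4-fold higher number from compound 2 to compound 4 (0.39 log units; beyond the scatter)), and the 3-hydroxyphenyl group cannot be told apart from the 2-(nitrooxy)phenyl group (a 1.6-fold lower number from compound 1 to compound 4 (0.21 log units; within the scatter)). Nothing available here accounts for the effect of moving the hydroxy group.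

The compounds shown leave open whether a 3-chlorophenyl group would differ from the 4-chlorophenyl group in the same direction. They also leave open how a 2-hydroxyphenyl or a 3-aminophenyl group would compare at this place.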